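The source may hold more compounds than are shown below. What is called first, only, known or untested is meant among the compounds shown, and "the series" means these compounds.

Measured so far in a functional assay (Oryctolagus cuniculus) for inhibition of platelet-activating factor receptor (Cavia porcellus); on this read-out higher numbers stand for weaker inhibition and lower numbers for stronger inhibition:
- compound 1, `CCCCCCCCCCCCCCCCCC1OCC(COCCCCCC[N+](C)(C)C)O1`: 2400 nM
- compound 2, `CCCCCCCCCCCCCCCCCC1OCC(COCCCCCC[n+]2cscc2C)O1`: 3100 nM

The gap between the two measured numbers is a 1.3-fold higher number from compound 1 to compound 2 (0.11 log units; within the scatter), so compound 1 and compound 2 stand level within the scatter.

Compound 3, `CCCCCCCCCCCCCCCCCC1OCC(COCCCCCC[n+]2cccc3ccccc32)O1`, is not yet measured. Its change from compound 2 is a group of 10 heavy atoms (9 carbon, 1 nitrogen; one six-membered aromatic ring of carbon only, one six-membered aromatic ring with 1 hetero atom) in place of a group of 6 heavy atoms (4 carbon, 1 nitrogen, 1 sulfur; one five-membered aromatic ring with 2 hetero atoms), on a saturated chain carbon, six bonds along the chain from an oxygen on a saturated carbon. Within the data shown here, the only measured step that bears on this position is the one from the open chain cation to the five-membered aromatic cation, a 1.3-fold higher number from compound 1 to compound 2 (0.11 log units; within the scatter), which is within the scatter. With one step and no change beyond the scatter to go on, the expectation is that the swap at this position again moves the number little, and no direction beyond the scatter is predicted. The estimate for compound 3 in this assay is therefore 3000 nM, range 1000 nM to 9000 nM, corresponding to an expected step of a 1.0-fold lower number from compound 2 to compound 3 (0.01 log units; within the scatter).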

Compound 3, half-maximal inhibitory concentration: 2700 nM
Compound 3: middle estimate off by 1.1-fold (0.05 log units), on the high side; low and high end bracket the measured number.
By their numbers in this assay, from the lowest: compounds 1, 3 and 2 (each within the scatter of the next).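

In this assay, a third form of the cationic group at this position leaves the number within the scatter: a 1.1-fold lower number from compound 2 to compound 3 (0.06 log units; within the scatter), and a 1.1-fold higher number from compound 1 to compound 3 (0.05 log units; within the scatter). The larger group, with one six-membered aromatic ring of carbon only and one six-membered aromatic ring with 1 hetero atom, therefore stands level both with the five-membered aromatic ring with 2 hetero atoms and with the group without a ring, so among compound 1, compound 2 and compound 3, neither ring type nor group size separates the numbers. No measured evidence bears on why these groups stand level.

On these data alone, all three groups carry a net charge of +1, so it remains open whether a neutral tertiary amine or a carboxylic acid at this position would give a similar number. As far as these compounds go, whether a longer chain carrying the cation would move the number beyond the scatter is also open.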